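The compounds below may be only part of what the source reports. "The series", "measured", "known", "first", "only" and "open" are said of these compounds alone.

In a functional assay on T47D cells (Homo sapiens) for inhibition, read by CCK-8 assay, with a stated time of 72 h, tested at 10 uM (on this read-out lower numbers stand for less inhibition of growth and higher numbers for more inhibition of growth at the one concentration tested), compound 2 `CN(C)C(=O)c1cc2cnc(Nc3ccc(NC(=O)C4(C(=O)Nc5cccc(Cl)c5)CC4)cc3)nc2n1C1CCCC1` gives 92.6% and compound 1 `CN(C)C(=O)c1cc2cnc(Nc3ccc(NC(=O)C4(C(=O)Nc5cccc(O)c5)CC4)cc3)nc2n1C1CCCC1` gives 83.7%, two numbers within the scatter of each other. Compound 3 `COc1cccc(NC(=O)C2(C(=O)Nc3ccc(Nc4ncc5cc(C(=O)N(C)C)n(C6CCCC6)c5n4)cc3)CC2)c1` carries methoxy in place of chloro on an aromatic carbon, meta to a large group: methoxy in place of chloro on an aromatic carbon. Going by the values given here, the only measured step at this place is a number 8.9 percentage points higher from compound 1 to compound 2 (within the scatter), for chloro in place of hydroxy, so no step beyond the scatter is expected in this assay. The expected change is small, a number 4.6 percentage points lower from compound 2 to compound 3 (within the scatter). For compound 3 the estimated value is 88%, with an expected range of 76% to 97%.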

Compound 3, percent growth inhibition at one concentration: 93.5%
For compound 3 the middle estimate is 5.5 percentage points below the measured one; low and high end bracket the measured number.
By their numbers in this assay, from the lowest: compounds 1, 2 and 3 (each within the scatter of the next).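

In this assay, methoxy in place of chloro gives a number 0.9 percentage points higher from compound 2 to compound 3 (within the scatter), and methyl on the oxygen of the hydroxy group gives a number 9.8 percentage points higher from compound 1 to compound 3 (within the scatter). Hydroxy, chloro and methoxy on this aromatic carbon therefore all lie within the scatter of one another, and this single-concentration read-out does not separate them. No measured property bears on this result. Still open, on these data alone, is whether an amine or a carboxylic acid on this carbon would move the number beyond the scatter. Also open, as far as these compounds go, is whether these three compounds would separate at lower concentrations.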